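Lengthening the Alkyl Chain of Compound 2

This account rests on a few compounds, and the source may have more. Where it says the series, first, only, none or still open, it means among the compounds named here.

Compound 1 `CCCCCCCCCCCCCCCCc1nc(N2CCC2)nc(OC2CCC2)c1O` gave 100% in a functional assay on cells (Lymphocyte, Homo sapiens), read by a luciferase reporter and ATP content, with a stated time of 48 h, tested at 1 uM; a lower number here means a stronger effect, a higher number a weaker effect of the compound at the concentration tested.
Compound 2 `CCCCCCCCCCCCCCc1nc(N2CCC2)nc(N2CCC2)c1O` gave 86% in this assay.

Compound 2 holds the lower of the two numbers, and compound 1 sits higher, beyond the scatter; as the two differ in more than one place, only their values can be set side by side. The unmeasured compound 3 `CCCCCCCCCCCCCCCCc1nc(N2CCC2)nc(N2CCC2)c1O` differs from compound 2 by ethyl in place of hydrogen on a saturated chain carbon, ten or more bonds along the chain from an aromatic carbon. Among the compounds with values here, no single-change step between measured compounds is at hand, so the size of this step is uncertain, but the same chain as in compound 3 is carried by compound 1, which gives 100%. A small step upward, within the scatter, of a number 6 percentage points higher from compound 2 to compound 3 (within the scatter) is expected. Compound 3 is estimated at 92%, between 80% and 104%.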

Compound 3, a percentage reported as activity, at one concentration (the size of the read-out at that concentration, not a potency): 92%
Estimate against measurement, compound 3: no gap at the digits printed; measured number inside the range.
By their numbers in this assay, from the lowest: compounds 2, 3 and 1 (each within the scatter of the next, the first and the last beyond it).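

In this assay, ethyl in place of hydrogen on a saturated chain carbon, ten or more bonds along the chain from an aromatic carbon, gives a number 6 percentage points higher from compound 2 to compound 3 (within the scatter), so this change cannot be told apart from no effect. Azetidin-1-yl in place of cyclobutyloxy on an aromatic carbon gives a number 8 percentage points lower from compound 1 to compound 3 (within the scatter), so this exchange likewise shows no clear effect. No measurement at hand offers an explanation for either step. On these data alone, whether a longer chain, or morpholin-4-yl in place of azetidin-1-yl on an aromatic carbon, would move the number beyond the scatter remains open.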